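Compound 1 to compound 4: ethoxy in place of fluoro

A few compounds are considered here, and "the series" means these few. Any claim that something is new, unique, unknown or untested is made for them only; others in the source may bear on it.

Measured in a toxicity assay on MDCK cells (Canis lupus familiaris) for cytotoxicity, read by crystal violet staining, with a stated time of 48 h; on this read-out lower numbers stand for higher toxicity in this test and higher numbers for lower toxicity in this test:
- compound 1 `Cc1ccc2[nH]c(=O)c(CN(Cc3ccc(F)cc3)Cc3ccc(C(C)(C)C)cc3)cc2c1`: > 27000 nM (a limit)
- compound 2 `CC(C)c1ccc2[nH]c(=O)c(CN(Cc3ccc(F)cc3)Cc3ccc(C(C)(C)C)cc3)cc2c1`: 7900 nM
- compound 3 `Cc1ccc2[nH]c(=O)c(CN(Cc3ccc(F)cc3)Cc3cccc4ccccc34)cc2c1`: > 5000 nM (a limit)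

Compound 1 has no number in this assay, only the limit > 27000 nM. Compound 3 likewise has only a limit, > 5000 nM. The next analogue is compound 4 `CCOc1ccc(CN(Cc2ccc(C(C)(C)C)cc2)Cc2cc3cc(C)ccc3[nH]c2=O)cc1`, with ethoxy in place of fluoro on an aromatic carbon, para to a large group: ethoxy in place of fluoro on an aromatic carbon.

For the measured compounds named here, no measured step touches this place. The nearest guide is an at least 3.4-fold lower number from compound 1 to compound 2 (0.53 log units; beyond the scatter), which comes from isopropyl in place of methyl on an aromatic carbon elsewhere in the molecule. The exchange of 4-(tert-butyl)phenyl for naphthalen-1-yl gives a step that the two limits leave unreadable from compound 1 to compound 3, so it offers no size to carry over. On this thin basis, a modest move to a lower number is expected, and a further limit remains possible. The expected change is an at least 1.9-fold lower number from compound 1 to compound 4 (0.28 log units; that floor lies within the scatter). For compound 4 the estimated value is 14000 nM, with an expected range of 5000 nM to 35000 nM.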

Compound 4, half-maximal cytotoxic concentration: > 10000 nM
Compound 4 ended at the assay's limit; the forecaster's own chance of this, stated with the estimate: 35%; the middle value lies beyond the limit too.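

In this assay, compound 1 and compound 4 each carry only a limit, and the step between them cannot be read. The compounds shown leave open whether ethoxy in place of fluoro shifts the half-maximal cytotoxic concentration at all, and in which direction.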